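The compounds below may be only part of what the source reports. "The series", "measured", "known", "first", "only" and "open" are said of these compounds alone.

Among the compounds with values here, compound 2 `CC(C)(C)C1=C(C(=O)O)N2C(=O)[C@H]([C@H](O)CCc3ccc(O)cc3)[C@H]2O1` gives 24.6 h in an ADME assay, in phosphate buffer, at 28 degrees C, at pH 7.0 (on this read-out lower numbers stand for a shorter-lived compound and higher numbers for a longer-lived compound), the higher of the two numbers measured so far. Within the data shown here, compound 1 `C[C@@H](O)[C@H]1C(=O)N2C(C(=O)O)=C(C(C)(C)C)O[C@H]12` gives 8.1 h in this assay, and the only measured step, a 3.0-fold higher number from compound 1 to compound 2 (0.48 log units; beyond the scatter), adds a 4-hydroxybenzyl group rather than changing a stereocentre. Compound 3 `CC(C)(C)C1=C(C(=O)O)N2C(=O)[C@H]([C@@H](O)CCc3ccc(O)cc3)[C@@H]2O1` differs from compound 2 only in configuration: the two compounds have the same atoms and bonds and differ only in configuration as drawn: 2 of 3 stereo elements differ; a stereocentre at a saturated chain carbon is drawn R in compound 2 and S in compound 3; a stereocentre at a saturated ring carbon is drawn R in compound 2 and S in compound 3. Among the measured compounds shown here, no measured step involves such a change, so no direction can be read from the data, and a step within the scatter, a 1.0-fold lower number from compound 2 to compound 3 (0.01 log units; within the scatter), is expected. Compound 3 is therefore estimated at 24 h in this assay, with a range from 10 h to 50 h.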

Compound 3, half-life: 11.8 h
Compound 3: the middle estimate sits 2.0-fold (0.31 log units) above what was measured; low and high end bracket the measured number.
By their numbers in this assay, from the lowest: compounds 1 and 3 (each within the scatter of the next); then compound 2.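

In this assay, configuration alone moves the number, with a 2.1-fold lower number from compound 2 to compound 3 (0.32 log units; beyond the scatter). The earlier step showed only the effect of adding a 4-hydroxybenzyl group, whereas here nothing enters or leaves. The shift can be tied to stereochemistry because nothing else separates this pair: the fact that compounds 2 and 3 differ only in the configuration as drawn.

Going by these compounds, the stereocentres at the saturated chain carbon and the saturated ring carbon change together, so the share of each remains open. Also open, on these data alone, is whether an amine in place of the hydroxyl on the 4-hydroxybenzyl group would show the same sensitivity to configuration.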